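Aryl Swap in a Series With Little Inhibition

The source may hold more compounds than are shown below. What is called first, only, known or untested is meant among the compounds shown, and "the series" means these compounds.

Of the compounds shown here, three have been measured in an assay on CHO cells for displacement of a labelled ligand from adenosine receptor A3 (Homo sapiens), read by scintillation counting, tested at 10 uM; on this read-out lower numbers stand for less inhibition and higher numbers for more inhibition at the one concentration tested (going by the name of the read-out). Compound 1 `CC(C)Cc1csc(N)c1C(=O)c1ccc(Cl)cc1` gives 1%, compound 2 `CC(C)(C)Cc1csc(N)c1C(=O)c1cccc(Cl)c1` gives 8%, and compound 3 `CC(C)(C)Cc1c(-c2cccnc2)sc(N)c1C(=O)c1ccc(Cl)cc1` gives 1%. Compound 3 stands level with compound 1 at the digits shown, the two together being the lowest of the three numbers, while compound 2 differs from them by a gap that stays within the usual scatter, so none of the three can be ranked against another. Compound 4 `COc1cccc(-c2sc(N)c(C(=O)c3ccc(Cl)cc3)c2CC(C)(C)C)c1` differs from compound 3 by one change: 3-methoxyphenyl in place of pyridin-3-yl on an aromatic carbon. Going by the values given here, no step between measured compounds is available to gauge this change. Among the compounds with values here, with every value so far near the bottom of the scale, compound 4 is expected to show no step beyond the scatter, a number 4 percentage points higher from compound 3 to compound 4 (within the scatter). Compound 4 is therefore estimated at 5%, within 0% to 25%.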

Compound 4, a percentage reported as inhibition, at one concentration (the size of the read-out at that concentration, not a potency): 1%
Estimate against measurement, compound 4: 4 percentage points above, and the stated range covers the measured number.
By their numbers in this assay, from the lowest: compounds 1, 3, 4 and 2 (each within the scatter of the next).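

In this assay, 3-methoxyphenyl in place of pyridin-3-yl on the aromatic carbon next to the ring sulfur gives no change at the digits printed from compound 3 to compound 4 (within the scatter). Going by these compounds alone, this is the only step read at this position, and it shows that exchanging a six-membered aromatic ring with one hetero atom for a carbon-only one bearing methoxy leaves the number unmoved. Nothing available bears on the reason for this. With both numbers near the bottom of the scale, a flat step says little about what this position allows. Going by these compounds, whether an aminomethyl group or a carboxylic acid here would lift the number beyond the scatter remains open.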